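Replacing the 2-methoxyethyl group of compound 2

The source may report more compounds than this note shows. Statements on the series, on what has been measured and on what is new or still open speak of the compounds shown alone.

Measured in a physicochemical assay for lipophilicity, read by HPLC, at pH 7.4; a lower number here means a more polar compound, a higher number a more lipophilic compound:
Compound 1 `C[C@@H](Oc1cc2cnn(CCC(=O)O)c2cc1Cl)c1ccccn1`: 1.7
Compound 2 `COCCOc1cc2oc(=O)n(CCC(=O)O)c2cc1Cl`: 0.88

Of these two numbers, compound 2 holds the lower, and the gap to compound 1 lies beyond the scatter. Compound 3 `C[C@@H](Oc1cc2oc(=O)n(CCC(=O)O)c2cc1Cl)c1cccnn1` differs from compound 2 in one place, on an oxygen on an aromatic ring: a group of 8 heavy atoms (6 carbon, 2 nitrogen; one six-membered aromatic ring with 2 hetero atoms) in place of a group of 4 heavy atoms (3 carbon, 1 oxygen; no ring), on an oxygen on an aromatic ring. For the measured compounds named here, no measured pair isolates this change, so its size can only be judged indirectly. Compound 1, whose group on the matching oxygen also holds an aromatic ring, reads 1.7, but its core differs as well, so only part of that gap is expected to carry over. A modest rise in this assay is therefore expected, not far beyond the scatter. The expected change is a number 0.32 log units higher from compound 2 to compound 3 (beyond the scatter). For compound 3 the estimated value is 1.2, with an expected range of 0.75 to 1.65.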

Compound 3, distribution coefficient: 0.83
Compound 3: middle estimate off by 0.37 log units, on the high side; the range from low to high includes it.
By their numbers in this assay, from the lowest: compounds 3 and 2 (each within the scatter of the next); then compound 1.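

In this assay, putting the group of 8 heavy atoms with its six-membered aromatic ring on the oxygen in place of 2-methoxyethyl gives a number 0.05 log units lower from compound 2 to compound 3 (within the scatter), so the two compounds cannot be told apart. On this shared core, then, the oxygen on an aromatic ring carries the larger, ring-bearing group with no reading separable from that of the open chain, and the added heavy atoms alone do not shift the number beyond the scatter. No measurement at hand offers an explanation for this result.

Open, from the compounds shown here alone, is how a phenyl ring, with no hetero atoms, or an amine-bearing chain would read on this same oxygen. The compounds shown also do not separate the contribution of the aromatic ring from that of the defined stereocentre, which enter together in compound 3.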